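An Ethyl Group Enters Where a Methyl Stood

This account rests on a few compounds, and the source may have more. Where it says the series, first, only, none or still open, it means among the compounds named here.

Measured so far in an assay on HEK293 cells for inhibition of sodium-dependent dopamine transporter (Homo sapiens), read by scintillation counting, with a stated time of 5 min; a lower number here means a stronger inhibitor, a higher number a weaker inhibitor:
Compound 1, `CCC(=O)N(Cc1ccc2ccccc2c1)[C@@H]1CCNC1`: 266 nM
Compound 2, `Cc1c(C(=O)N(C(C)C)[C@@H]2CCNC2)ccc(Cl)c1Cl`: > 40000 nM
Compound 3, `Cc1c(C(=O)N(C)[C@@H]2CCNC2)ccc(Cl)c1Cl`: "not determined" (no result reported)

Compound 3 has no number of its own in this assay; of the three values shown, one is a plain number and one is a limit. Compound 1 gives 266 nM. For compound 2 the value > 40000 nM is a limit of the assay and not a number. The limit is described as the limit of > 40000 nM in this assay, at which 1 of the 3 values shown sits. Compound 3 shares its core with compound 2 and differs from it only in the group on the amide-type nitrogen, yet the two cannot be compared on numbers, since compound 3 has none.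

Compound 4, `CCN(C(=O)c1ccc(Cl)c(Cl)c1C)[C@@H]1CCNC1`, is the next step: methyl in place of hydrogen on a saturated chain carbon bound to an amide-type nitrogen. Within the data shown here, no measured pair shows how this kind of change plays out on this core. Among the measured compounds shown here, compound 2, carrying a larger group on the same nitrogen, sits at the limit, and compound 1, with a different core, is the only one with a plain number. Compound 4 is therefore expected to land somewhere between these two, and its estimated value in this assay is 8000 nM, with a range from 1000 nM to 40000 nM.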

Compound 4, half-maximal inhibitory concentration: > 40000 nM
Compound 4 gave a limit, no number; the forecaster's own chance of this, stated with the estimate: 35%; at least 5.0-fold (0.69 log units) between middle value and limit.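

Compound 4 gives > 40000 nM in this assay, which is a limit of the assay and not a number. No step can be read from compound 2 to compound 4, because both compounds sit at the same limit: the limit of > 40000 nM in this assay, at which 2 of the 4 values shown sit.

The compounds shown leave open whether any group on the amide-type nitrogen of this shared core gives a plain number.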